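Aryl group change on the shared core

The source may hold more compounds than are shown below. What is called first, only, known or untested is meant among the compounds shown, and "the series" means these compounds.

Among the measured compounds shown here, in a functional assay on MCF7 cells (Homo sapiens) for antiproliferative activity, read by MTT assay, with a stated time of 72 h (on this read-out higher numbers stand for weaker inhibition and lower numbers for stronger inhibition), compound 2 (`COc1cc(-n2cnc3ccc(-c4ccc(C)cc4)cc32)cc(OC)c1OC`) gives 110 nM, the lower of the two numbers so far, while compound 1 (`COc1cc(-n2cnc3ccc(-c4cccc(F)c4)cc32)cc(OC)c1OC`) gives 2350 nM. Compound 3 (`COc1cccc(-c2ccc3ncn(-c4cc(OC)c(OC)c(OC)c4)c3c2)c1`) has 3-methoxyphenyl in place of 4-methylphenyl on an aromatic carbon. For the measured compounds named here, only one measured step bears on this change: a 21-fold lower number from compound 1 to compound 2 (1.33 log units; beyond the scatter), a large step with 4-methylphenyl in place of 3-fluorophenyl. Going by the values given here, no measured compound carries 3-methoxyphenyl, and two compounds cannot show how far the 3-fluorophenyl result extends to it. The 3-methoxyphenyl group shares its 3-substituted name with the group of compound 1, so a move toward that compound's higher number is expected, probably only part of the way. The expected step is a 5.5-fold higher number from compound 2 to compound 3 (0.74 log units; beyond the scatter). For compound 3 the estimate is 600 nM, with an expected range of 130 nM to 2800 nM.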

Compound 3, half-maximal inhibitory concentration: 1610 nM
Beside the measured number, compound 3's estimate is 2.7-fold (0.43 log units) below it, and the stated range covers the measured number.
By their numbers in this assay, from the lowest: compound 2; then compounds 3 and 1 (each within the scatter of the next).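

In this assay, 3-methoxyphenyl in place of 4-methylphenyl gives a 15-fold higher number from compound 2 to compound 3 (1.17 log units; beyond the scatter), so a second 3-substituted phenyl group also stands well apart from compound 2. Methoxy in place of fluoro gives a 1.5-fold lower number from compound 1 to compound 3 (0.16 log units; within the scatter), which lies within the scatter: the two 3-substituted phenyl groups cannot be told apart here, and compound 2 alone holds the low number. Nothing at hand bears on the reason for this gap.

The compounds shown leave open whether the low number goes with methyl itself or with a substituent in the 4-place of the phenyl ring. As far as these compounds go, a 3-methylphenyl and a 4-methoxyphenyl group on the shared core would separate these two readings, and the effect of an amine or a carboxylic acid on that phenyl ring also remains open.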